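Swapping isobutyl for sec-butyl on an aromatic nitrogen

The source may hold more compounds than are shown below. What is called first, only, known or untested is meant among the compounds shown, and "the series" means these compounds.

Three measured compounds share one core and differ only in the alkyl group on an aromatic nitrogen: compound 1 `CCCCn1cc(C(=O)O)c(=O)c2c(O)c(Cc3cccc(Cl)c3F)ccc21` carries butyl, compound 2 `CC(C)n1cc(C(=O)O)c(=O)c2c(O)c(Cc3cccc(Cl)c3F)ccc21` carries isopropyl and compound 3 `CC(C)Cn1cc(C(=O)O)c(=O)c2c(O)c(Cc3cccc(Cl)c3F)ccc21` carries isobutyl. In an ADME assay on C8166 cells (Homo sapiens) for cytotoxicity, read by MTT assay (on this read-out higher numbers stand for lower toxicity in this test and lower numbers for higher toxicity in this test), compound 1 gives 20000 nM, compound 2 gives 26500 nM and compound 3 gives 19500 nM. Compound 3 thus lies within the usual scatter of both others, so these numbers do not rank it against them.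

Within the data shown here, compound 4 `CCC(C)n1cc(C(=O)O)c(=O)c2c(O)c(Cc3cccc(Cl)c3F)ccc21` keeps the core and changes only that group, with sec-butyl in place of isobutyl on an aromatic nitrogen. Among the measured compounds shown here, no measured step makes this exact exchange, so the nearest guides are the exchanges among the other groups at the same place. These are a 1.3-fold higher number from compound 1 to compound 2 (0.12 log units; within the scatter), a 1.0-fold lower number from compound 1 to compound 3 (0.01 log units; within the scatter) and a 1.4-fold lower number from compound 2 to compound 3 (0.13 log units; within the scatter). All of them stay within the scatter, so among these compounds, changing the group has not shifted the number measurably. No step beyond the scatter, in either direction, is therefore expected in this assay. The expected step is a 1.1-fold higher number from compound 3 to compound 4 (0.05 log units; within the scatter). For compound 4 the estimated value is 22000 nM, with an expected range from 13000 nM to 36000 nM.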

Compound 4, half-maximal cytotoxic concentration: 30700 nM
Compound 4: middle estimate off by 1.4-fold (0.14 log units), on the low side; the range from low to high includes it.
By their numbers in this assay, from the lowest: compounds 3, 1, 2 and 4 (each within the scatter of the next).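

In this assay, rearranging the same carbon atoms from isobutyl to sec-butyl gives a 1.6-fold higher number from compound 3 to compound 4 (0.20 log units; within the scatter) and so does not separate the two groups, even though this is the largest step seen so far at this position. The other two new steps are a 1.5-fold higher number from compound 1 to compound 4 (0.19 log units; within the scatter) for sec-butyl in place of butyl and a 1.2-fold higher number from compound 2 to compound 4 (0.06 log units; within the scatter) for a methyl in place of hydrogen on the chain, so all four alkyl groups on this aromatic nitrogen, straight or branched, now give numbers that cannot be told apart. Nothing is available here to explain why the numbers fall where they do.

All four groups are plain saturated alkyl chains, which leaves open whether a ring such as cyclopropyl or benzyl, a longer chain such as hexyl, or a chain bearing a hydroxyl or an amine would move the number beyond the scatter. Going by these compounds, it also remains open whether these groups would stay equally hard to tell apart in any test other than this assay.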